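Adding a methoxy to compounds at the assay limit

The source may report more compounds than this note shows. Statements on the series, on what has been measured and on what is new or still open speak of the compounds shown alone.

Measured in a functional assay on K562 cells (Homo sapiens) for inhibition, read by sulforhodamine B assay, with a stated time of 48 h; on this read-out higher numbers stand for weaker inhibition of growth and lower numbers for stronger inhibition of growth; each value is a limit, not a number:
- Compound 1 `CC1(/C=C/c2ccc(F)cc2)C=CC(=O)O1`: > 1000000 nM
- Compound 2 `COc1ccc(/C=C/C2(C)C=CC(=O)O2)c(OC)c1`: > 1000000 nM
- Compound 3 `COc1ccc(/C=C/C2(C)C=CC(=O)O2)cc1OC`: > 1000000 nM

Compound 3 has no true number, only the limit > 1000000 nM. It shares this position with compounds 1 and 2, as the limit of > 1000000 nM in this assay, at which 3 of the 3 values shown sit, shows. Compound 4 `COc1ccc(/C=C/C2(C)C=CC(=O)O2)c(OC)c1OC` carries methoxy in place of hydrogen on an aromatic carbon. Among the measured compounds shown here, no pair of measured compounds differs in one place, so no measured step guides this change. The expected change in this assay is none beyond the scatter, with a number no higher from compound 3 to compound 4 (the limit leaves the size open) as the estimated step. Compound 4 is estimated at 1000000 nM, with an expected range from 300000 nM to 3000000 nM.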

Compound 4, concentration for total growth inhibition: > 1000000 nM
Compound 4 gave a limit, no number (the forecaster's own chance of this, stated with the estimate: 85%); the middle value lies on the limit itself.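

Compound 4, like compound 2 and compound 3, gives only a limit, so neither methoxy step can be read: the limit of > 1000000 nM in this assay, at which 4 of the 4 values shown sit. Whether adding methoxy changes growth inhibition in this assay at all stays open, since none of these compounds has a true number.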